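This account rests on a few compounds, and the source may have more. Where it says the series, first, only, none or still open, it means among the compounds named here.

In a functional assay on LS174T cells (Homo sapiens) for cytotoxicity (on this read-out lower numbers stand for stronger inhibition and higher numbers for weaker inhibition), compound 1 (`Nc1cccc(SC(=O)NC(CCC(=O)O)C(=O)O)c1`) gives > 5000000 nM, which is a limit of the assay and not a number. Compound 2 (`COc1cccc(SC(=O)NC(CCC(=O)O)C(=O)O)c1`) gives > 500000 nM, also a limit, so its standing is known only as a limit. Among the measured compounds shown here, the one measured step, a step that the two limits leave unreadable from compound 1 to compound 2, therefore offers no size to carry forward. Compound 3 (`Cc1cccc(SC(=O)NC(CCC(=O)O)C(=O)O)c1`) differs from compound 2 by methyl in place of methoxy on an aromatic carbon, with methyl in place of methoxy on an aromatic carbon, meta to a large group. For the measured compounds named here, neither compound measured so far gives a readable number, and no direction can be drawn from them, so compound 3 is expected to remain weak in this assay, quite possibly reported only as a limit. The expected change is a step that the limit leaves unreadable from compound 2 to compound 3, an estimate with no direction supported by the data. For compound 3 the estimated value is 700000 nM, with an expected range from 200000 nM to 5000000 nM.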

Compound 3, half-maximal inhibitory concentration: > 500000 nM
Compound 3 was reported as a limit; the forecaster's own chance of this, stated with the estimate: 85%; the middle value lies beyond the limit too.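

Compound 3, like compound 1 and compound 2, is reported in this assay only as a limit, so no step among these three compounds can be read. The compounds shown leave open whether compound 1, compound 2 and compound 3 differ at all in this assay.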